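Indolyl in Place of Methoxyphenyl: Expected Cytotoxicity

The compounds below may be only part of what the source reports. "The series", "measured", "known", "first", "only" and "open" are said of these compounds alone.

Compound 1, `CC(C)N(Cc1cccc(OCCCCCC(=O)O)c1)C(=O)c1ccc(-c2ccco2)cc1`: > 26000 nM
Compound 2, `COc1cccc(-c2ccc(C(=O)N(Cc3cccc(OCCCCCC(=O)O)c3)C(C)C)cc2)c1`: > 26000 nM

Compound 1 carries a furan-2-yl group on the shared core. In an ADME assay on HepG2 cells (Homo sapiens) for cytotoxicity, read by CellTiter-Glo and resazurin assay, with a stated time of 72 h (on this read-out lower numbers stand for an effect already at smaller amounts and higher numbers for an effect only at larger amounts of compound), compound 1 gives > 26000 nM, which is a limit of the assay rather than a measured number. Compound 2 carries a 3-methoxyphenyl group at the same position, and in this assay compound 2 also gives > 26000 nM, again only a limit. The change between them, a step that the two limits leave unreadable from compound 1 to compound 2, therefore cannot be read, because of the limit of > 26000 nM in this assay, at which 2 of the 2 values shown sit.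

Compound 3, `CC(C)N(Cc1cccc(OCCCCCC(=O)O)c1)C(=O)c1ccc(-c2ccc3cc[nH]c3c2)cc1`, differs from compound 2 by one change: 1H-indol-6-yl in place of 3-methoxyphenyl on an aromatic carbon. For the measured compounds named here, the only measured step that bears on this position is the unreadable one from compound 1 to compound 2, so no size or direction can be taken from it, and compound 2 itself stands only at the limit.

On this basis, compound 3 is expected to show no cytotoxic effect within the tested range, most likely again as a limit in this assay. The estimate for compound 3 is 30000 nM, with a range from 10000 nM to 100000 nM. The expected step that the limit leaves unreadable from compound 2 to compound 3 is none beyond the usual scatter.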

Compound 3, half-maximal effective concentration: > 26000 nM
Compound 3: only a limit was reported; the forecaster's own chance of this, stated with the estimate: 80%; the middle value does not contradict the limit.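

In this assay compound 3 gives > 26000 nM, again a limit and not a number. The steps to compound 3 from compound 1 and from compound 2 therefore cannot be read, for this reason: the limit of > 26000 nM in this assay, at which 3 of the 3 values shown sit.

As far as these compounds go, how compound 1, compound 2 and compound 3 compare, and at what concentration any of them would become cytotoxic, stays open.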